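The source may report more compounds than this note shows. Statements on the series, on what has been measured and on what is new or still open speak of the compounds shown alone.

Measured so far in an assay on CHO-K1 cells for displacement of a labelled ligand from adenosine receptor A1 (Homo sapiens), tested at 10 uM; on this read-out lower numbers stand for less inhibition and higher numbers for more inhibition at the one concentration tested (going by the name of the read-out):

- Compound 1, `CCOC(=O)c1c(N)sc(-c2ccccc2)c1-c1cccc(C(F)(F)F)c1`, gives 83.6%
- Compound 2, `CCOC(=O)c1c(N)sc(-c2ccc(C(F)(F)F)cc2)c1-c1cccc(C(F)(F)F)c1`, gives 48.5%

Compound 2 stands at the lower of the two numbers; its nearest neighbour is compound 1, and the step between them, a number 35.1 percentage points lower from compound 1 to compound 2 (beyond the scatter), is beyond the usual scatter. That step is the only measured one, and it shows that putting a trifluoromethyl group on the aromatic carbon that carries hydrogen in compound 1 cost a large share of the inhibition.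

Compound 3, `CCOC(=O)c1c(N)sc(-c2ccc(-c3ccncc3)cc2)c1-c1cccc(C(F)(F)F)c1`, is not yet measured. It differs from compound 2 in one place: pyridin-4-yl in place of trifluoromethyl on an aromatic carbon. The new group is larger than the one it replaces and brings one hydrogen-bond acceptor into that position.

For the measured compounds named here, the only step that bears on this change is the one from compound 1 to compound 2, which shows that this position is sensitive to what sits on it, with a large loss when trifluoromethyl entered. Nothing measured tells whether a pyridin-4-yl group will behave like the trifluoromethyl, worse, or recover toward compound 1. The expectation is therefore a modest further decrease, a number 13.5 percentage points lower from compound 2 to compound 3 (beyond the scatter), with wide uncertainty. Compound 3 is estimated at 35%, in a range from 10% to 65%.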

Compound 3, a percentage reported as inhibition, at one concentration (the size of the read-out at that concentration, not a potency): 91%
Estimate against measurement, compound 3: 56 percentage points below, outside the stated range (above it).
By their numbers in this assay, from the lowest: compound 2; then compounds 1 and 3 (each within the scatter of the next).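

In this assay, replacing trifluoromethyl with pyridin-4-yl gives a number 42.5 percentage points higher from compound 2 to compound 3 (beyond the scatter), so the loss seen with trifluoromethyl does not extend to every group placed on this aromatic carbon. The comparison with hydrogen gives a number 7.4 percentage points higher from compound 1 to compound 3 (within the scatter), which means that this pyridin-4-yl group, with its six-membered aromatic ring, shows no loss against hydrogen, and that among these three compounds a group with more heavy atoms does not by itself bring a lower number. Nothing available explains why trifluoromethyl and pyridin-4-yl give such different results at this position.

As far as these compounds go, it remains open whether the ring nitrogen of the pyridin-4-yl group matters, and a phenyl or a pyridin-3-yl group on the same carbon would help separate the effect of the ring from that of the nitrogen and its placement. Groups such as methyl, an amine or a carboxylic acid at this position could also show whether the drop belongs to trifluoromethyl alone or extends to other small groups.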